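Plasma Stability Expected for Compound 4

A few compounds are considered here, and "the series" means these few. Any claim that something is new, unique, unknown or untested is made for them only; others in the source may bear on it.

The account starts from compound 1 `C[C@@H](O)[C@H]1C(=O)N2C(C(=O)O)=C(S[C@@H]3CN[C@H](C(=O)Nc4cccc(C(=O)OCC(F)(F)F)c4)C3)[C@H](C)[C@H]12`, for which an ADME assay on a cell-free system (plasma, Rattus norvegicus) for metabolic stability, read by LC-MS, with a stated time of 60 min, at 37 degrees C, tested at 50 uM (on this read-out higher numbers stand for a more stable compound and lower numbers for a less stable compound), gives "not determined" (no result reported); compound 1 therefore stands nowhere on the values shown, and the size of its step to compound 4 cannot be placed against a measured starting point. Two other compounds were measured. Compound 2 `C[C@@H](O)[C@H]1C(=O)N2C(C(=O)OCC(F)(F)F)=C(S[C@@H]3CN[C@H](C(=O)Nc4cccc(C(=O)OCC(F)(F)F)c4)C3)[C@H](C)[C@H]12` gives 3% in this assay, and compound 3 `Cc1oc(=O)oc1COC(=O)N1C[C@@H]2C[C@H]1C(=O)Nc1cccc(c1)C(=O)OCc1oc(=O)oc1COC(=O)C1=C(S2)[C@H](C)[C@@H]2[C@@H]([C@@H](C)O)C(=O)N12` gives 0% in this assay; the two values lie within the usual scatter of each other, so no order is read between them. Compound 4 `C[C@@H](O)[C@H]1C(=O)N2C(C(=O)O)=C(S[C@@H]3CN[C@H](C(=O)Nc4cccc(C(=O)OCOC(=O)C(C)(C)C)c4)C3)[C@H](C)[C@H]12` is not yet measured. It differs from compound 1 by ((tert-butyl)carbonyl)oxy in place of trifluoromethyl on a saturated chain carbon bound to an oxygen next to a carbonyl group, the change sitting on a saturated chain carbon bound to an oxygen next to a carbonyl group. With no value for compound 1, no size or direction of step in this assay can be stated for compound 4 beyond the expectation that it will sit low, as compound 2 and compound 3 do. Compound 4 is expected to give 3% in this assay, estimated to fall between 0% and 15%.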

Compound 4, percent of the compound remaining in the plasma assay: 0%
Compound 4: the middle estimate sits 3 percentage points above what was measured, within the range that was stated.
By their numbers in the plasma assay, from the lowest: compounds 3, 4 and 2 (each within the scatter of the next).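

No new step can be read between compound 1 and compound 4. In a physicochemical assay for metabolic stability, read by LC-MS, in phosphate buffer, with a stated time of 3 h, at pH 7.4, tested at 50 uM (on this read-out higher numbers stand for a more stable compound and lower numbers for a less stable compound), compound 1 gives > 95%, which is a limit of the assay. In the physicochemical assay compound 4 gives > 95%, also a limit. The two compounds share one bound: the limit of > 95% in the physicochemical assay, at which 2 of the 2 values shown sit.

The compounds shown leave open how compound 1 stands against compound 4 in the plasma assay, and how far apart the two lie in the physicochemical assay.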